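This account rests on a few compounds, and the source may have more. Where it says the series, first, only, none or still open, it means among the compounds named here.

Series notes. The set in hand comprises compound 1 `COc1cccc(N2C(N)=NC(N)=NC23CCN(C(=O)c2ccc(C(F)(F)F)cc2C)CC3)c1`, compound 2 `CC(C)(C)OC(=O)N1CCC2(CC1)N=C(N)N=C(N)N2Cc1cccc(Cl)c1`, compound 3 `CCCN1C(N)=NC(N)=NC12CCN(C(=O)C1CC1)CC2` and the still unmeasured compound 4 `CCCN1C(N)=NC(N)=NC12CCN(C(=O)c1c(C)noc1C)CC2`. All readings to date come from an ADME assay on HeLa cells (Homo sapiens) for cytotoxicity, read by microscopy, with a stated time of 6 days; a higher number here means that more compound is tolerated, a lower number that less compound is tolerated. In this assay compound 1 gives only a limit of the assay, > 100000 nM. In this assay compound 2 likewise reaches only a limit, > 100000 nM. In this assay compound 3 also stops at a limit, > 100000 nM. Within the data shown here, compound 3 thus stands together with the others at the limit of > 100000 nM in this assay, at which 3 of the 3 values shown sit; no measured compound returns a number, so no step between measured compounds can be drawn and nothing separates the three.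

Compound 4 differs from compound 3 in one place: 3,5-dimethyl-1,2-oxazol-4-yl in place of cyclopropyl on a carbonyl carbon. Among the measured compounds shown here, no measured pair carries this change, so its effect in this assay is unknown; the expectation is simply that compound 4 behaves like every compound measured so far, which is at the limit. The step from compound 3 to compound 4 is expected to be a number no higher from compound 3 to compound 4 (the limit leaves the size open), that is, none beyond the scatter. Compound 4 is expected to give about 100000 nM in this assay, with a range from 50000 nM to 200000 nM, most probably reported once more as a limit rather than as a number.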

Compound 4, minimum cytotoxic concentration: > 100000 nM
Compound 4 was reported as a limit (the forecaster's own chance of this, stated with the estimate: 85%); the middle value lies on the limit itself.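

No step can be read between compound 3 and compound 4, because both stop at a limit in this assay: the limit of > 100000 nM in this assay, at which 4 of the 4 values shown sit.

The compounds shown leave open at what concentration any of them becomes cytotoxic in this assay, and whether 3,5-dimethyl-1,2-oxazol-4-yl in place of cyclopropyl on a carbonyl carbon changes that concentration at all.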